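The compounds below may be only part of what the source reports. "The series", "measured", "known", "first", "only" and "open" are said of these compounds alone.

Measured compounds:
Compound 1, `COc1cc(/C=C/C(=O)O)ccc1OC(=O)c1nc(C)c(C)nc1C`, 40.3%
Compound 2, `CCOC(=O)/C=C/c1cc(OC)ccc1OC(=O)c1nc(C)c(C)nc1C`, 23.4%
Compound 3, `Cc1nc(C)c(C(=O)Oc2ccc(/C=C/C(=O)O)cc2)nc1C`, 46.6%

All three were tested in a functional assay on EA.hy 926 cells (Homo sapiens) for cytotoxicity, read by MTT assay, with stated times of 24 h and 12 h, tested at 25 uM; on this read-out higher numbers stand for a stronger effect at the one concentration tested and lower numbers for a weaker effect. Compound 3, `Cc1nc(C)c(C(=O)Oc2ccc(/C=C/C(=O)O)cc2)nc1C`, and compound 1, `COc1cc(/C=C/C(=O)O)ccc1OC(=O)c1nc(C)c(C)nc1C`, differ by one change, (hydrogen in place of methoxy on an aromatic carbon), and the step of a number 6.3 percentage points higher from compound 1 to compound 3 (within the scatter) lies within the scatter, so the two values cannot be put in order. Compound 2, `CCOC(=O)/C=C/c1cc(OC)ccc1OC(=O)c1nc(C)c(C)nc1C`, gives the lowest number of the three, and the difference between its core and the core of compound 1 is not broken down here.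

Compound 4, `CCOC(=O)/C=C/c1ccccc1OC(=O)c1nc(C)c(C)nc1C`, is not yet measured. It differs from compound 2 by hydrogen in place of methoxy on an aromatic carbon. This is the same kind of change as that from compound 1 to compound 3, though the surroundings are not the same: in the earlier case the hydrogen enters ortho to a large group and meta to a 2-carboxyethenyl group, here meta to a 2-(ethoxycarbonyl)ethenyl group and para to a large group. Resting on the small step of a number 6.3 percentage points higher from compound 1 to compound 3 (within the scatter), the step from compound 2 to compound 4 is expected to be of similar size, a number 4.6 percentage points higher from compound 2 to compound 4 (within the scatter). Compound 4 is therefore estimated at 28%, between 14% and 42%.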

Compound 4, a percentage reported as activity, at one concentration (the size of the read-out at that concentration, not a potency): 17.8%
For compound 4 the middle estimate is 10.2 percentage points above the measured one; the range from low to high includes it.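

Hydrogen in place of methoxy on an aromatic carbon gives, in this assay, a number 5.6 percentage points lower from compound 2 to compound 4 (within the scatter), so these two values cannot be put in order. Set beside the earlier case, the two steps carry opposite signs, yet the gap between them does not exceed the scatter: the same change on two cores in this assay, a number 6.3 percentage points higher (within the scatter) from compound 1 to compound 3 and a number 5.6 percentage points lower (within the scatter) from compound 2 to compound 4, 11.9 percentage points apart, within the scatter of two such steps. Within the data shown here, on both cores, then, the change leaves no step that can be read, and the two cores cannot be told apart in their response to it; this does not show that the change has no effect, only that any effect stays hidden in the scatter, and the comparison rests on two pairs alone.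

The compounds shown leave open whether another group in the place of the methoxy, such as a hydroxyl, a chlorine or an amine, would give a step that can be read. Also open, going by these compounds, is whether the change would behave the same way with an amide or a longer ester chain in place of the carboxylic acid or ethyl ester.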